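The source may hold more compounds than are shown below. What is called first, only, known or untested is meant among the compounds shown, and "the series" means these compounds.

Among the three measured compounds, compound 2 `Cn1ncc(Cl)c1-c1cc(C(=O)N[C@@H]2CN[C@H](CCn3cncn3)C[C@H]2c2ccc(Cl)c(Cl)c2)oc1Cl` stands second highest in an assay for inhibition of RAC-alpha serine/threonine-protein kinase (Homo sapiens), read by HTRF, with a stated time of 1 h (on this read-out lower numbers stand for stronger inhibition and higher numbers for weaker inhibition), where compound 2 gives 4.47 nM. Compound 3 `Cn1ncc(Cl)c1-c1cc(C(=O)N[C@@H]2CN[C@H](CCO)C[C@H]2c2ccc(F)c(F)c2)oc1Cl` gives 0.98 nM, a stronger inhibition, while compound 1 `Cn1ncc(Cl)c1-c1cc(C(=O)NC2CNCC2c2ccc(C(F)(F)F)cc2)oc1Cl` gives 538 nM, far weaker than either.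

The step to compound 4 `CN(C)CC[C@@H]1C[C@@H](c2ccc(Cl)c(Cl)c2)[C@H](NC(=O)c2cc(-c3c(Cl)cnn3C)c(Cl)o2)CN1` changes one group on the chain attached to the saturated ring: dimethylamino in place of 1H-1,2,4-triazol-1-yl on a saturated chain carbon, two bonds along the chain from a saturated ring carbon. Within the data shown here, no pair of measured compounds shows this exact change, so there is no measured step to lean on; compound 2 and compound 3 differ in several places at once and show only that changes at this chain position can go along with strong inhibition.

For compound 4 the step of a 1.3-fold lower number from compound 2 to compound 4 (0.11 log units; within the scatter) is expected to be small, with no clear direction beyond the scatter, giving an estimated 3.5 nM with a range from 1 nM to 12 nM.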

Compound 4, half-maximal inhibitory concentration: 3.4 nM
For compound 4 the middle estimate is 1.0-fold (0.01 log units) above the measured one, within the range that was stated.
By their numbers in this assay, from the lowest: compound 3; then compounds 4 and 2 (each within the scatter of the next); then compound 1.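

In this assay, among these compounds, dimethylamino in place of 1H-1,2,4-triazol-1-yl gives a 1.3-fold lower number from compound 2 to compound 4 (0.12 log units; within the scatter) and offers the first comparison that changes this chain position alone. For this pair, inhibition stays at a similar level whether the chain ends in a five-membered aromatic ring or in a group with no ring. Nothing measured here explains why the two groups read alike. Going by these compounds, a carboxylic acid or morpholine at the end of the 2-carbon chain remains open, as does a longer chain carrying dimethylamino.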